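Moving a dimethylamino group between two ring positions

The source may report more compounds than this note shows. Statements on the series, on what has been measured and on what is new or still open speak of the compounds shown alone.

Compound 1 `Cc1cccc(Nc2nccc(-c3ccncc3)n2)c1` and compound 2 `Cc1ccccc1Nc1nccc(-c2ccncc2)n1` are made of the same atoms joined differently; the difference between the two cores is not broken down here. In a functional assay for inhibition, with Homo sapiens as the target (a higher number here means a weaker inhibitor, a lower number a stronger inhibitor), compound 1 gives 8800 nM, while compound 2 gives 3900 nM. Compound 3 `CN(C)c1ccccc1Nc1nccc(-c2ccncc2)n1` gives 36200 nM. Compound 3 differs from compound 2 by dimethylamino in place of methyl on an aromatic carbon, and this brought a 9.3-fold higher number from compound 2 to compound 3 (0.97 log units; beyond the scatter). Compound 4 `CN(C)c1cccc(Nc2nccc(-c3ccncc3)n2)c1` differs from compound 1 by dimethylamino in place of methyl on an aromatic carbon. This is the same kind of change, though the group now sits meta to a large group rather than ortho to a large group. The step into compound 4 is expected to weaken inhibition as well, estimated at a 4.0-fold higher number from compound 1 to compound 4 (0.60 log units; beyond the scatter), because a 9.3-fold higher number from compound 2 to compound 3 (0.97 log units; beyond the scatter) went that way. For compound 4 the expected value in this assay is 35000 nM, plausibly between 12000 nM and 100000 nM.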

Compound 4, half-maximal inhibitory concentration: 3700 nM
The estimate for compound 4 lay 9.5-fold (0.98 log units) above the measured number; measured number outside the range, below it.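

The swap of methyl for dimethylamino gave a 2.4-fold lower number from compound 1 to compound 4 (0.38 log units; beyond the scatter) in this assay, so on this core the change strengthened inhibition rather than weakening it. The result on one core therefore gave no safe guide to the result on the other, in size or in direction: the same change on two cores in this assay, a 9.3-fold higher number (0.97 log units; beyond the scatter) from compound 2 to compound 3 and a 2.4-fold lower number (0.38 log units; beyond the scatter) from compound 1 to compound 4, 22-fold (1.34 log units) apart, beyond the scatter of two such steps. Among these compounds, these two pairs show only that the change did not carry over here; they do not show why, and they cannot support a rule for any further core.

From the compounds shown here alone, it remains open how a methoxy group or a longer chain in place of the methyl would behave on either core.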